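The source may report more compounds than this note shows. Statements on the series, on what has been measured and on what is new or still open speak of the compounds shown alone.

Compound 2 `COc1ccc(-n2cc(CNC(=O)c3cccc4c3cnn4C(C)C)nn2)cc1` has been measured in a functional assay on PC-3 cells (Homo sapiens) for inhibition, read by MTT assay, with a stated time of 72 h (a higher number here means a weaker inhibitor, a lower number a stronger inhibitor), where compound 2 gives 34300 nM. For the measured compounds named here, its only measured neighbour, compound 1 `CC(C)n1ncc2c(C(=O)NCc3cn(-c4cccc(Br)c4)nn3)cccc21`, gives 33700 nM in this assay, so the two sit within the scatter of each other. Going by the values given here, the single step available, a 1.0-fold higher number from compound 1 to compound 2 (0.01 log units; within the scatter), exchanges one substituted phenyl for another on the aromatic nitrogen and leaves the number essentially unchanged. Compound 3 `COc1ccc(Cn2cc(CNC(=O)c3cccc4c3cnn4C(C)C)nn2)cc1` differs from compound 2 by 4-methoxybenzyl in place of 4-methoxyphenyl on an aromatic nitrogen. Among the compounds with values here, no measured step addresses a change of this kind, in which a phenyl becomes a benzyl on that nitrogen, so the only guide is how closely compound 1 and compound 2 agree. On that basis a step of a 1.0-fold lower number from compound 2 to compound 3 (0.00 log units; within the scatter) is expected, meaning no movement beyond the scatter, with a deliberately wide range. Compound 3 is therefore estimated at 34000 nM, between 12000 nM and 95000 nM.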

Compound 3, half-maximal inhibitory concentration: 34000 nM
For compound 3 middle estimate and measured number coincide at the digits printed; the range from low to high includes it.
By their numbers in this assay, from the lowest: compounds 1, 3 and 2 (each within the scatter of the next).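

The earlier pair exchanged only one substituted phenyl for another, with the ring bound directly to the aromatic nitrogen. Compound 3 adds the benzyl carbon between ring and nitrogen, and the step of a 1.0-fold lower number from compound 2 to compound 3 (0.00 log units; within the scatter) shows that in this assay this change does not move the number beyond the scatter. The wider exchange, a 1.0-fold higher number from compound 1 to compound 3 (0.00 log units; within the scatter), also stays within the scatter, so the three aromatic groups at this position cannot be told apart in this assay, and nothing available accounts for that.

As far as these compounds go, all three compounds carry a substituted six-membered aromatic ring at this position, so it remains open whether this nitrogen tolerates any substituent or only these. From the compounds shown here alone, what a basic amine, a carboxylic acid or a longer alkyl chain would give there is unknown.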